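Aromatic substituent changes on the pendant phenyl ring

The compounds below may be only part of what the source reports. "The series", "measured", "known", "first", "only" and "open" are said of these compounds alone.

Compound 1, `CCCS(=O)(=O)Nc1ccc(F)c(C(=O)c2n[nH]c3ncc(-c4ccccc4)cc23)c1F`, gives 2.4% in an assay for binding affinity to dual specificity mitogen-activated protein kinase kinase 4 (Homo sapiens), read by KINOMEscan, tested at 100 nM; on this read-out higher numbers stand for a weaker effect at the one concentration tested and lower numbers for a stronger effect. Compound 2, `CCCS(=O)(=O)Nc1ccc(F)c(C(=O)c2n[nH]c3ncc(-c4ccc(F)cc4)cc23)c1F`, gives 2.1% in this assay. Compound 3, `CCCS(=O)(=O)Nc1ccc(F)c(C(=O)c2n[nH]c3ncc(-c4ccc(O)cc4)cc23)c1F`, gives 0.75% in this assay.

All three share one core and differ only in what sits on the outer phenyl ring. Compound 3 shows the lowest number of the three, but the steps that reach it, a number 1.7 percentage points lower from compound 1 to compound 3 (within the scatter) and a number 1.4 percentage points lower from compound 2 to compound 3 (within the scatter), are both within the scatter, as is a number 0.3 percentage points lower from compound 1 to compound 2 (within the scatter), so the three compounds cannot be told apart on this read-out.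

Compound 4, `CCCS(=O)(=O)Nc1ccc(F)c(C(=O)c2n[nH]c3ncc(-c4ccc(N)cc4)cc23)c1F`, differs from compound 3 by amino in place of hydroxy on an aromatic carbon. The steps measured so far all concern the same aromatic carbon, exchanging hydrogen, fluoro and hydroxy, and none of them moved the number beyond the scatter. Among the compounds with values here, no measured step covers amino itself, so the expectation rests on the observation that this position has so far tolerated each change without a visible effect in this assay.

Compound 4 is therefore expected to give about 1.5% in this assay, with a range from 0.3% to 6%. The expected step of a number 0.8 percentage points higher from compound 3 to compound 4 (within the scatter) is estimated to stay within the scatter.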

Compound 4, a percentage reported as activity, at one concentration (the size of the read-out at that concentration, not a potency): 0.1%
Beside the measured number, compound 4's estimate is 1.4 percentage points above it, and the stated range ends above it.
By their numbers in this assay, from the lowest: compounds 4, 3, 2 and 1 (each within the scatter of the next).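

Amino joins hydrogen, fluoro and hydroxy as a fourth group on this aromatic carbon, para to a large group, that produces no step beyond the scatter in this assay: the change from 4-hydroxyphenyl to 4-aminophenyl gives a number 0.7 percentage points lower from compound 3 to compound 4 (within the scatter), while the comparisons with the fluoro and hydrogen analogues give a number 2 percentage points lower from compound 2 to compound 4 (within the scatter) and a number 2.3 percentage points lower from compound 1 to compound 4 (within the scatter). Compound 4 therefore cannot be separated from any of the other three compounds on this read-out, so exchanging the oxygen of hydroxy for the nitrogen of amino adds no visible difference, and the position's tolerance now extends to a fourth group. No accompanying information bears on why this result arises.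

What a carboxylic acid, a dimethylamino group or a morpholine on this same aromatic carbon would do remains open, and each would test this tolerance with a group unlike the four shown. Also open, going by these compounds, is whether these four compounds would separate on a read-out that gives a potency rather than the size of the effect at one concentration.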